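Swapping a Branch for a Small Ring on the Chain

The compounds below may be only part of what the source reports. "The series", "measured", "known", "first", "only" and "open" are said of these compounds alone.

Of the compounds shown here, three built on a shared core have been measured in a functional assay on CHO cells for positive allosteric modulation of metabotropic glutamate receptor 2 (Homo sapiens), with a stated time of 30 min; a higher number here means a larger maximal response, a lower number a smaller maximal response. Compound 1 `CC(C)CCn1ccc(CCc2ccccc2)c(C#N)c1=O` gives 168%. Compound 2 `CC(C)CCn1ccc(N(C)Cc2ccccc2)c(C#N)c1=O` gives 249%. Compound 3 `CC(C)Cn1ccc(N2CCC(c3ccccc3)CC2)c(C#N)c1=O` gives 316%, the highest of the three; compound 2 stands below it by a gap beyond the scatter, and compound 1 stands lower still. Compound 4 `N#Cc1c(N2CCC(c3ccccc3)CC2)ccn(CCC2CC2)c1=O` differs from compound 3 in one place: cyclopropylmethyl in place of isopropyl on a saturated chain carbon bound to an aromatic nitrogen. Within the data shown here, no measured pair isolates this change, so its effect on the maximal response is not known from the data. Compound 4 is expected to give about 310%, in a range from 270% to 350%. The expected step of a number 6 percentage points lower from compound 3 to compound 4 (within the scatter) would stay within the usual scatter.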

Compound 4, largest response reached (Emax), in percent of the reference or control that the assay uses: 316%
Estimate against measurement, compound 4: 6 percentage points below; low and high end bracket the measured number.
By their numbers in this assay, from the lowest: compound 1; then compound 2; then compounds 3 and 4 (each within the scatter of the next).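

In this assay, putting cyclopropylmethyl in place of isopropyl on a saturated chain carbon bound to an aromatic nitrogen gives no change at the digits printed from compound 3 to compound 4 (within the scatter). Among these compounds, this is the first pair to isolate a change at this position, and it shows that the maximal response holds when a small carbon ring replaces the branch. Nothing available explains why the response holds. Going by these compounds, whether the response would also hold with an amine or a carboxylic acid at the end of this chain remains open, as does the outcome with a longer chain.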